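Changing the Chain on the Core Nitrogen: Compound 3 to 4

This account rests on a few compounds, and the source may have more. Where it says the series, first, only, none or still open, it means among the compounds named here.

Three compounds share one core and differ only in the group attached to a saturated chain carbon bound to an aromatic nitrogen. In a functional assay on MCF7 cells (Homo sapiens) for antiproliferative activity (on this read-out lower numbers stand for stronger inhibition and higher numbers for weaker inhibition), compound 1 `COc1cc(Cc2nc3c(N)ncnc3n2CCOC(C)C)cc(OC)c1OC` gives 38900 nM, compound 2 `COc1cc(Cc2nc3c(N)ncnc3n2CC2CC2)cc(OC)c1OC` gives 75900 nM, and compound 3 `COc1cc(Cc2nc3c(N)ncnc3n2CC2CCCO2)cc(OC)c1OC` gives 91200 nM, the highest of the three numbers. The steps of a 2.3-fold higher number from compound 1 to compound 3 (0.37 log units; beyond the scatter) and a 1.2-fold higher number from compound 2 to compound 3 (0.08 log units; within the scatter) show that swapping groups at this place has moved the result only a little.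

Compound 4 `C/C=C/Cn1c(Cc2cc(OC)c(OC)c(OC)c2)nc2c(N)ncnc21` carries prop-1-en-1-yl in place of oxolan-2-yl on a saturated chain carbon bound to an aromatic nitrogen. This is a fresh group at the same place that the measured steps explored, and those steps were small, so no change beyond the scatter is expected in this assay; the step of a 1.3-fold lower number from compound 3 to compound 4 (0.11 log units; within the scatter) is the expected outcome. For compound 4 the estimated value in this assay is 70000 nM, with a range from 25000 nM to 200000 nM.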

Compound 4, half-maximal inhibitory concentration: 51300 nM
For compound 4 the middle estimate is 1.4-fold (0.13 log units) above the measured one, and the stated range covers the measured number.
By their numbers in this assay, from the lowest: compounds 1, 4, 2 and 3 (each within the scatter of the next, the first and the last beyond it).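

In this assay, for the compounds shown here, the but-2-en-1-yl chain of compound 4 is the only group here with neither a ring nor an oxygen, yet all its steps lie within the scatter: (a 1.8-fold lower number from compound 3 to compound 4 (0.25 log units; within the scatter)), (a 1.5-fold lower number from compound 2 to compound 4 (0.17 log units; within the scatter)) and (a 1.3-fold higher number from compound 1 to compound 4 (0.12 log units; within the scatter)). Replacing oxolan-2-yl, with its ring and hydrogen-bond acceptor, therefore produces no change that can be told from repeat-measurement scatter, and the same holds for the steps from the cyclopropyl and isopropoxymethyl groups. No supporting measurement is available to explain this result.

The groups shown are all small and uncharged, so it remains open whether an amine, a carboxylic acid or a longer chain at this place would move the number beyond the scatter. These compounds also cannot show whether changes elsewhere on the shared core would matter more.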